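The source may hold more compounds than are shown below. What is called first, only, known or untested is meant among the compounds shown, and "the series" means these compounds.

In an assay on NIH3T3 cells with melatonin receptor type 1A (Homo sapiens) as the target (a higher number here means a weaker inhibitor, a lower number a stronger inhibitor), compound 1 `CCC1Nc2cccc([C@@H]3C[C@H]3CNC(C)=O)c2O1` gives 0.35 nM. Compound 2 `CCC1Nc2cccc([C@@H]3C[C@H]3CNC(=O)C(C)C)c2O1` carries an isopropyl in place of a methyl on the carbonyl carbon; in this assay compound 2 gives 0.2 nM, and the step of a 1.8-fold lower number from compound 1 to compound 2 (0.24 log units; within the scatter) stays within the scatter. Compound 3 `CCCC1Nc2cccc([C@@H]3C[C@H]3CNC(=O)C(C)C)c2O1` differs from compound 2 by a methyl in place of hydrogen on a saturated chain carbon, and in this assay compound 3 gives 4.9 nM. That single change brought a 25-fold higher number from compound 2 to compound 3 (1.39 log units; beyond the scatter), so compound 3 stands as the highest number of the three measured, well apart from both others.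

Compound 4 `CCCC1Nc2cccc([C@@H]3C[C@H]3CNC(=O)NCC)c2O1` is reached from compound 3 by ethylamino in place of isopropyl on a carbonyl carbon, while the longer chain of compound 3 is kept. Among the compounds with values here, no measured step exchanges the group on the carbonyl carbon for one containing nitrogen, so the direct evidence is thin. Within the data shown here, the only step at that place, a 1.8-fold lower number from compound 1 to compound 2 (0.24 log units; within the scatter), was within the scatter, which suggests the group there has little weight, whereas the large step of a 25-fold higher number from compound 2 to compound 3 (1.39 log units; beyond the scatter) sits on the chain, which compound 4 shares with compound 3. Compound 4 is therefore expected to move little, with a 1.0-fold higher number from compound 3 to compound 4 (0.01 log units; within the scatter) estimated to stay within the scatter. Compound 4 is expected to give about 5 nM, between 1.5 nM and 15 nM.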

Compound 4, inhibition constant: 3.5 nM
The estimate for compound 4 lay 1.4-fold (0.15 log units) above the measured number; the measured number falls inside the stated range.
By their numbers in this assay, from the lowest: compounds 2 and 1 (each within the scatter of the next); then compounds 4 and 3 (each within the scatter of the next).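

Within the data shown here, replacing isopropyl with ethylamino on the carbonyl carbon brings nitrogen and a hydrogen-bond donor to this place for the first time, yet in this assay the step is only a 1.4-fold lower number from compound 3 to compound 4 (0.15 log units; within the scatter). The earlier step at this carbonyl carbon, a 1.8-fold lower number from compound 1 to compound 2 (0.24 log units; within the scatter), was made with the chain of compound 2, whereas this one was made with the longer chain of compound 3, so both chains now show a change here that stays within the scatter. The measurements shown give no reason for this outcome.

On these data alone, it remains open whether ethylamino would leave the number just as unchanged on the chain of compound 2, since a step on that chain, a 25-fold higher number from compound 2 to compound 3 (1.39 log units; beyond the scatter), was large and the two changes might not simply add up. As far as these compounds go, it is also open how this carbonyl carbon would respond to dimethylamino, which has no hydrogen on its nitrogen, to ethoxy, or to a longer chain such as butyl or hexyl.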